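The source may hold more compounds than are shown below. What is called first, only, known or untested is meant among the compounds shown, and "the series" means these compounds.

Compound 1 `CCc1ccc(NC(=O)N(Cc2ccc(OC)c(OC)c2)n2cnnc2)cc1` — > 50000 nM
Compound 2 `N#Cc1ccc(CN(C(=O)Nc2cc(C(F)(F)F)cc(C(F)(F)F)c2)n2cnnc2)cc1` — 9280 nM
Compound 3 `Cc1ccsc1CN(C(=O)Nc1cccc(C#N)c1)n1cnnc1` — > 50000 nM

All three were tested in a functional assay on MDA-MB-231 cells (Homo sapiens) for cytotoxicity, read by MTT assay, with a stated time of 48 h; on this read-out lower numbers stand for stronger inhibition and higher numbers for weaker inhibition. Compound 1 gives > 50000 nM, which is a limit of the assay rather than a measured number. Compound 3 likewise gives a limit, > 50000 nM. Compound 1 therefore stands at the weak end of what was measured, sharing (the limit of > 50000 nM in this assay, at which 2 of the 3 values shown sit). Among the compounds with values here, compound 2 is the only one with a number in this assay, giving 9280 nM.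

Within the data shown here, no two of the measured compounds differ in only one place, so no measured step is available to anchor the next change. The unmeasured compound 4 `COc1ccc(CN(C(=O)Nc2ccc(F)c(Cl)c2)n2cnnc2)cc1OC` is compared with compound 1, from which it differs in one place: 3-chloro-4-fluorophenyl in place of 4-ethylphenyl on an amide-type nitrogen. Among the measured compounds shown here, with compound 1 resting at a limit and no step of this kind measured, the expected step from compound 1 to compound 4 is modest, an at least 1.4-fold lower number from compound 1 to compound 4 (0.15 log units; that floor lies within the scatter), a gain in potency that may not clear the scatter. The estimate for compound 4 is 35000 nM, with an expected range from 8000 nM to 100000 nM, and a real chance that this assay again returns only a limit.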

Compound 4, half-maximal inhibitory concentration: 27900 nM
Compound 4: the middle estimate sits 1.3-fold (0.10 log units) above what was measured, within the range that was stated.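

With 3-chloro-4-fluorophenyl in place of 4-ethylphenyl on the amide-type nitrogen, the cytotoxicity read-out in this assay yields an actual number, and compound 4 gives 27900 nM. Within the data shown here, this is the first step measured at this place, and it reads as an at least 1.7-fold lower number from compound 1 to compound 4 (0.25 log units; that floor lies within the scatter); the two groups have the same heavy-atom count, and each is a six-membered aromatic ring of carbon only, so the exchange swaps the substituents on that ring while the ring itself stays. The step is known only as a floor, and its true size stays open, because the value for compound 1 is a limit rather than a number: the limit of > 50000 nM in this assay, at which 2 of the 4 values shown sit.

The compounds shown leave open what a phenyl ring carrying an amine or a carboxylic acid, or a longer alkyl chain in place of the ring, would do on this same nitrogen. They also leave open whether the exchange from 4-ethylphenyl to 3-chloro-4-fluorophenyl gives a similar step when the rest of the molecule differs from the core of compound 1.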